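Chain variants on the shared core: sulfur-bearing step

The source may report more compounds than this note shows. Statements on the series, on what has been measured and on what is new or still open speak of the compounds shown alone.

Compound 1 `CCOCc1c(C)nc2c(OCc3ccccc3)cccn12`: 35%
Compound 2 `CCSCc1c(C)nc2c(OCc3ccccc3)cccn12`: 0%

In a functional assay on the whole organism (stomach) for inhibition, with Canis familiaris (Canis lupus familiaris) as the target, at a dose of 5 mg/kg by the intravenous route (on this read-out higher numbers stand for a stronger effect at the one dose given and lower numbers for a weaker effect), compound 1 gives 35% and compound 2 gives 0%. Compound 2 stands lowest of the two numbers; the nearest, compound 1, is separated by a number 35 percentage points lower from compound 1 to compound 2 (beyond the scatter). Compound 3 `Cc1nc2c(OCc3ccccc3)cccn2c1C[S+](C)[O-]` differs from compound 2 by a group of 3 heavy atoms (1 carbon, 1 oxygen, 1 sulfur; no ring) in place of a group of 3 heavy atoms (2 carbon, 1 sulfur; no ring), on a saturated chain carbon bound to an aromatic carbon. Within the data shown here, the only measured step, a number 35 percentage points lower from compound 1 to compound 2 (beyond the scatter), concerns the same place but not the same entering group; it shows that changes at this place can move the read-out by a large amount. Among the measured compounds shown here, no step in the same direction is known, so only a moderate rise is expected: a number 20 percentage points higher from compound 2 to compound 3 (beyond the scatter). Compound 3 is estimated at 20%, between 0% and 50%.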

Compound 3, a percentage reported as inhibition, in the whole organism at one dose (the size of the read-out at that dose, not a potency): 18%
For compound 3 the middle estimate is 2 percentage points above the measured one, within the range that was stated.
By their numbers in this assay, from the lowest: compound 2; then compound 3; then compound 1.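

In this assay the sulfur-containing group at this saturated chain carbon does not always abolish the read-out: a number 18 percentage points higher from compound 2 to compound 3 (beyond the scatter) while sulfur stays in the group. The change does not fully match the ethoxy chain, with a number 17 percentage points lower from compound 1 to compound 3 (beyond the scatter) and compound 1 keeping the highest number of the three. Nothing measured explains either step.

From the compounds shown here alone, whether an amine, a carboxylic acid or a butoxy chain at this carbon would exceed compound 1 remains open. With a single dose shown, these numbers speak only of a stronger or weaker effect at that dose.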